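The compounds below may be only part of what the source reports. "The series", "measured", "known", "first", "only" and "open" are said of these compounds alone.

In a functional assay on A549 cells (Homo sapiens) for cytotoxicity, read by sulforhodamine B assay (a lower number here means a stronger inhibitor of growth, a higher number a weaker inhibitor of growth), compound 1 `Cc1ccc2c(c1)CCCN2c1nc(C)nc2ccccc12` gives 211 nM and compound 2 `COc1ccc2c(c1)CCN2c1nc(C)nc2ccccc12` gives 268 nM, two values within the scatter of each other. Compound 3 `COc1ccc2c(c1)CCCN(c1nc(Cl)nc3ccccc13)C2` stands apart at 7570 nM, the highest of the three numbers and beyond the scatter from both of the others. Compound 4 `COc1ccc2c(c1)CCCN(c1nc(C)nc3ccccc13)C2` has yet to be measured. It differs from compound 3 in a single place, with methyl in place of chloro on an aromatic carbon. Going by the values given here, no measured pair isolates this exchange, so the evidence is indirect. Compound 1 at 211 nM and compound 2 at 268 nM both carry methyl at this place, but the rest of each structure differs from compound 4. A move toward a lower number, beyond the scatter, is therefore expected, though the gap may not close completely. The estimated step of a 9.5-fold lower number from compound 3 to compound 4 (0.98 log units; beyond the scatter) reflects that partial recovery. For compound 4 the expected value is 800 nM, with an estimated range of 150 nM to 4000 nM.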

Compound 4, concentration for 50% growth inhibition: 16700 nM
The estimate for compound 4 lay 21-fold (1.32 log units) below the measured number; the measured number lies above the stated range.
By their numbers in this assay, from the lowest: compounds 1 and 2 (each within the scatter of the next); then compound 3; then compound 4.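

In this assay, the exchange of chloro for methyl on the aromatic carbon between two ring nitrogen atoms gives a 2.2-fold higher number from compound 3 to compound 4 (0.34 log units; beyond the scatter) and so moves toward weaker growth inhibition, a modest step but beyond the scatter. Going by these compounds alone, this is the first direct reading of the change at this position, and it shows that on the core of compound 3 the chloro group is not what keeps the number high, since the number rises further with methyl in its place. Nothing available here explains the direction of this step. As far as these compounds go, whether the same exchange would move the number the same way on the cores of compound 1 and compound 2 remains open. Also open, from the compounds shown here alone, is how an amine or a longer chain such as ethyl would behave at this position on the core of compound 3.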